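Shortening Butylamino to Isopropylamino on a Shared Core

The source may report more compounds than this note shows. Statements on the series, on what has been measured and on what is new or still open speak of the compounds shown alone.

Measured so far:
- compound 1 `CCCCNc1nc(N)nc2c1ncn2/C=C1/CC1(CO)CO`
- compound 2 `Nc1nc(OCC(F)(F)F)c2ncn(/C=C3/CC3(CO)CO)c2n1`

In an ADME assay on BCBL1 cells (Homo sapiens) for cytotoxicity, with a stated time of 7 days (on this read-out higher numbers stand for lower toxicity in this test and lower numbers for higher toxicity in this test), compound 1 gives > 20000 nM, which is a limit of the assay rather than a number. In this assay compound 2 gives > 20000 nM, again only a limit. Among the measured compounds shown here, compound 1 therefore stands at a limit, and the one other value shown is a limit as well, so it cannot be placed above or below compound 2. For the measured compounds named here, the only measured step, a step that the two limits leave unreadable from compound 1 to compound 2, puts 2,2,2-trifluoroethoxy in place of butylamino on an aromatic carbon, and its size cannot be read because of the limit of > 20000 nM in this assay, at which 2 of the 2 values shown sit.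

Compound 3 `CC(C)Nc1nc(N)nc2c1ncn2/C=C1/CC1(CO)CO` has not yet been measured. It differs from compound 1 by isopropyl in place of butyl on a nitrogen on an aromatic ring. Going by the values given here, no measured step touches this part of the molecule, and the one step available is unreadable anyway. What the numbers show is that compound 1 sits at the limit and that butyl and isopropyl are both small alkyl groups, so nothing beyond the scatter is expected. For compound 3 the expected step is a step that the limit leaves unreadable from compound 1 to compound 3. Compound 3 is therefore estimated at 30000 nM in this assay, within 15000 nM to 80000 nM, most likely reported once more only as a limit.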

Compound 3, half-maximal cytotoxic concentration: > 20000 nM
Compound 3 was reported as a limit; the forecaster's own chance of this, stated with the estimate: 85%; the middle value lies beyond the limit too.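

No new step can be read among compound 1, compound 2 and compound 3, because all three rest on the same limit rather than on a number: the limit of > 20000 nM in this assay, at which 3 of the 3 values shown sit.

What the compounds shown leave open is whether butylamino, isopropylamino or 2,2,2-trifluoroethoxy on the shared core changes the read-out in this assay at all, and at what concentration any of the three would turn toxic to these cells.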